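A few compounds are considered here, and "the series" means these few. Any claim that something is new, unique, unknown or untested is made for them only; others in the source may bear on it.

Measured so far in a functional assay on MCF7 cells (Homo sapiens) for antiproliferative activity, read by MTT assay, with a stated time of 48 h; on this read-out higher numbers stand for weaker inhibition and lower numbers for stronger inhibition:

compound 1 `CC(=O)N1N=C(c2ccc3ccccc3c2)OC1c1ccccc1Cl` gives 2.36 ug/mL
compound 2 `CC(=O)N1N=C(c2ccc3ccccc3c2)OC1c1cccc(F)c1` gives 1.98 ug/mL

For the measured compounds named here, compound 1 holds the highest of the two numbers, and its only neighbour is compound 2, reached by a 1.2-fold lower number from compound 1 to compound 2 (0.08 log units; within the scatter). Compound 3 `CC(=O)N1N=C(c2ccc3ccccc3c2)OC1c1ccccc1[N+](=O)[O-]` arises from compound 1 by nitro in place of chloro on an aromatic carbon, read one bond further out as 2-chlorophenyl to 2-nitrophenyl. Going by the values given here, no measured step involves this exchange; the one step known, from compound 1 to compound 2, concerns a different phenyl substitution and stays within the scatter. Compound 3 is therefore expected to sit near compound 1, with a 1.1-fold higher number from compound 1 to compound 3 (0.03 log units; within the scatter) no larger than the scatter. The estimate for compound 3 is 2.5 ug/mL, between 1.2 ug/mL and 5 ug/mL.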

Compound 3, half-maximal inhibitory concentration: 18.2 ug/mL
Compound 3: the middle estimate sits 7.3-fold (0.86 log units) below what was measured; the whole stated range lies below it.
By their numbers in this assay, from the lowest: compounds 2 and 1 (each within the scatter of the next); then compound 3.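

In this assay, this aromatic carbon proves sensitive to what it carries: nitro in place of chloro gives a 7.7-fold higher number from compound 1 to compound 3 (0.89 log units; beyond the scatter), the first step beyond the scatter among these compounds and one towards weaker inhibition. The 2-nitrophenyl compound also stands apart from the 3-fluorophenyl compound, with a 9.2-fold higher number from compound 2 to compound 3 (0.96 log units; beyond the scatter). Nothing available accounts for this loss. Only chloro and nitro are shown on this carbon, so it stays open whether an amine or a carboxylic acid there would track compound 1 or compound 3.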